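The compounds below may be only part of what the source reports. "The series", "measured", "known", "first", "only" and "open" are said of these compounds alone.

Measured so far:
- compound 1 `COc1ccc2c(c1)NC(=O)CN2c1nc(Nc2cccc(C#N)c2)nc2ccccc12` gives 75.4 nM in a functional assay on A549 cells (Homo sapiens) for inhibition, read by sulforhodamine B assay, with a stated time of 48 h; a higher number here means a weaker inhibitor of growth, a lower number a stronger inhibitor of growth
- compound 2 `COc1ccc2c(c1)NC(=O)CN2c1nc(OCC2CC2)nc2ccccc12` gives 15.8 nM in this assay
- compound 3 `COc1ccc2c(c1)NC(=O)CN2c1nc(COCCCC(=O)NO)nc2ccccc12` gives 550 nM in this assay

Compound 3 has the highest number of the three, making it the weakest growth inhibitor here. The gaps to it are a 7.3-fold higher number from compound 1 to compound 3 (0.86 log units; beyond the scatter) and a 35-fold higher number from compound 2 to compound 3 (1.54 log units; beyond the scatter), both beyond the scatter.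

Compound 4 `CCOc1nc(N2CC(=O)Nc3cc(OC)ccc32)c2ccccc2n1` differs from compound 3 by ethoxy in place of (3-(hydroxycarbamoyl)propoxy)methyl on an aromatic carbon. For the measured compounds named here, the measured step that bears on this is the one between compound 2 and compound 3, since compound 2 also carries a short alkoxy group on the same carbon; that step was a 35-fold higher number from compound 2 to compound 3 (1.54 log units; beyond the scatter). Going the other way, a large drop in number is therefore expected for compound 4 in this assay, roughly a 22-fold lower number from compound 3 to compound 4 (1.34 log units; beyond the scatter). Compound 4 is estimated at 25 nM, with a range from 8 nM to 80 nM.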

Compound 4, concentration for 50% growth inhibition: 16.7 nM
For compound 4 the middle estimate is 1.5-fold (0.18 log units) above the measured one, and the stated range covers the measured number.
By their numbers in this assay, from the lowest: compounds 2 and 4 (each within the scatter of the next); then compound 1; then compound 3.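

In this assay, ethoxy on this carbon between the two ring nitrogen atoms gives a 33-fold lower number from compound 3 to compound 4 (1.52 log units; beyond the scatter) when it replaces (3-(hydroxycarbamoyl)propoxy)methyl, and a 4.5-fold lower number from compound 1 to compound 4 (0.65 log units; beyond the scatter) when it replaces (3-cyanophenyl)amino. Methyl in place of cyclopropyl on the chain gives a 1.1-fold higher number from compound 2 to compound 4 (0.02 log units; within the scatter), so ethoxy and cyclopropylmethoxy cannot be told apart here, and the small ring is not needed for this level of growth inhibition. Nothing shown explains these steps.

Going by these compounds, whether a methoxy group or a longer alkoxy chain would keep the number this low remains open. So does the result for a simple amine on this carbon.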